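Swapping 2-bromophenoxy for benzyl on a chain carbon

The source may hold more compounds than are shown below. What is called first, only, known or untested is meant among the compounds shown, and "the series" means these compounds.

Measured in a functional assay for inhibition, with Homo sapiens as the target; a lower number here means tighter binding, a higher number weaker binding:
- compound 1 `O=C(O)CC/C=C\CC1COC(c2ccc(Cl)cc2Cl)OC1c1cccnc1`: 891 nM
- compound 2 `O=C(O)CC/C=C\CC1COC(c2cccnc2)OC1c1cccnc1`: 759 nM
- compound 3 `CC(C)(Oc1ccccc1Br)C1OCC(C/C=C\CCC(=O)O)C(c2cccnc2)O1`: 63.1 nM

A lower number here means tighter binding, and compound 3 has the lowest number of the three, clearly beyond the scatter from both of the others.

Compound 4 `CC(C)(Cc1ccccc1)C1OCC(C/C=C\CCC(=O)O)C(c2cccnc2)O1` has not yet been measured. It carries benzyl in place of 2-bromophenoxy on a saturated chain carbon bound to two saturated chain carbons and a saturated ring carbon. Both groups contain one six-membered aromatic ring of carbon only.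

For the measured compounds named here, only one measured step is available, a 1.2-fold lower number from compound 1 to compound 2 (0.07 log units; within the scatter), and it lies within the scatter. That swap sits on a saturated ring carbon, not on this chain carbon, so it is only a weak guide here. Going by the values given here, no measured pair isolates the 2-bromophenoxy group, which occurs only in compound 3 at 63.1 nM. A moderate move towards a higher number therefore seems likely, though with wide uncertainty, and no return to the level of compound 2 at 759 nM is expected.

The expected step is a 2.4-fold higher number from compound 3 to compound 4 (0.38 log units; beyond the scatter). For compound 4 the estimated value in this assay is 150 nM, with an expected range from 45 nM to 500 nM.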

Compound 4, dissociation constant: 513 nM
Beside the measured number, compound 4's estimate is 3.4-fold (0.53 log units) below it; measured number outside the range, above it.
By their numbers in this assay, from the lowest: compound 3; then compounds 4, 2 and 1 (each within the scatter of the next).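

In this assay this chain carbon turns out to be sensitive to what it carries: benzyl in place of 2-bromophenoxy gives an 8.1-fold higher number from compound 3 to compound 4 (0.91 log units; beyond the scatter) even though both groups hold one six-membered aromatic ring of carbon only. The ring alone therefore does not preserve the low number, and what leaves with the swap is an oxygen and a bromine. The 1-benzyl-1-methylethyl group also offers no clear gain on the saturated ring carbon: in place of pyridin-3-yl it gives a 1.5-fold lower number from compound 2 to compound 4 (0.17 log units; within the scatter) and in place of 2,4-dichlorophenyl it gives a 1.7-fold lower number from compound 1 to compound 4 (0.24 log units; within the scatter) and both steps stay within the scatter. Nothing measured here explains the change at the chain carbon.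

Still open, from the compounds shown here alone, is whether the oxygen, the bromine or the two together account for the step, since they leave in a single swap. A plain phenoxy group without bromine and a 2-bromobenzyl group on the same chain carbon would pull those two apart.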